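Moving the pyridine nitrogen: from compound 2 to compound 3

This account rests on a few compounds, and the source may have more. Where it says the series, first, only, none or still open, it means among the compounds named here.

The measured compounds:
compound 1, `COc1ccc(/C=C/C[C@H]2C[C@@H]([C@@H](OC)c3ccc(OC)c(OC)c3)CO[C@@H]2c2ccc(OC)c(OC)c2)cc1OC`, with 4.8%
compound 2, `O[C@@H](c1ccccc1)[C@H]1CO[C@H](c2ccccc2)[C@@H](C/C=C/c2cccnc2)C1`, with 4%

In a functional assay on HeLa cells (Homo sapiens) for cytotoxicity, read by WST assay, with a stated time of 48 h, tested at 100 uM (a lower number here means less inhibition, a higher number more inhibition at the concentration tested (going by the name of the read-out)), compound 1 gives 4.8%, and compound 2 gives 4%. The two numbers lie within the scatter of each other, so neither compound can be set apart from the other; both show little inhibition at the concentration tested. Compound 2 is the point of departure for the next compound.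

Compound 3, `O[C@@H](c1ccccc1)[C@H]1CO[C@H](c2ccccc2)[C@@H](C/C=C/c2ccncc2)C1`, has the same atoms as compound 2, joined differently:

pyridin-4-yl in place of pyridin-3-yl on a double-bonded chain carbon bound to a double-bonded chain carbon

For the measured compounds named here, no step between two measured compounds is available for this kind of change, so there is nothing in the measured set to say how much the position of the ring nitrogen matters here. Compound 2 shows almost no inhibition in this assay, and the step expected for compound 3, a number 1 percentage points higher from compound 2 to compound 3 (within the scatter), is none beyond the scatter. Compound 3 is therefore estimated to give 5% in this assay, within a range from -5% to 15%.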

Compound 3, a percentage reported as inhibition, at one concentration (the size of the read-out at that concentration, not a potency): 34%
Compound 3: the middle estimate sits 29 percentage points below what was measured, outside the stated range (above it).
By their numbers in this assay, from the lowest: compounds 2 and 1 (each within the scatter of the next); then compound 3.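

In this assay, the place of the ring nitrogen proves to count at this position: pyridin-4-yl in place of pyridin-3-yl on a double-bonded chain carbon bound to a double-bonded chain carbon gives a number 30 percentage points higher from compound 2 to compound 3 (beyond the scatter). For the compounds shown here, the two groups have the same atoms and the same counts of hydrogen-bond donors and acceptors, so a change in how the atoms are joined is enough to lift compound 3 out of the scatter around the low numbers of the earlier compounds, which had offered no step at this place and no sign that this end of the chain could affect the read-out. Nothing in the data shown accounts for the size of this step.

The compounds shown leave open whether the step belongs to pyridin-4-yl alone or would also appear with pyridin-2-yl or a plain phenyl at the same place. They also leave open whether it would survive a longer chain between the core and the ring, or an amine on that ring.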